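Methyl in Place of Methoxy: What to Expect for Compound 4

The source may report more compounds than this note shows. Statements on the series, on what has been measured and on what is new or still open speak of the compounds shown alone.

Three compounds have been measured in a functional assay on cells (Homo sapiens) for cytotoxicity, read by MTT assay, with a stated time of 24 h; on this read-out higher numbers stand for weaker inhibition and lower numbers for stronger inhibition:

Compound 1, `CCCCCCCCCCCCCCNC(=O)[C@H](CO)NCc1ccccc1OC`, gives 100000 nM.
Compound 2, `CCCCCCCCCCCCCCNC(=O)[C@H](CO)/N=C/c1ccccc1OC`, gives 12500 nM.
Compound 3, `CCCCCCCCCCCCCCNC(=O)[C@H](CO)/N=C/c1ccc(Cl)cc1`, gives 27500 nM.

Compound 2 stands lowest of the three numbers. Its nearest neighbour is compound 3, separated by a 2.2-fold higher number from compound 2 to compound 3 (0.34 log units; beyond the scatter), and the furthest is compound 1, separated by an 8.0-fold lower number from compound 1 to compound 2 (0.90 log units; beyond the scatter). Both of these steps are modest but beyond the scatter, so compound 2 is the strongest inhibitor in this set on the measured numbers.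

Compound 4, `CCCCCCCCCCCCCCNC(=O)[C@H](CO)/N=C/c1ccccc1C`, differs from compound 2 by methyl in place of methoxy on an aromatic carbon. Of the measured steps, only a 2.2-fold higher number from compound 2 to compound 3 (0.34 log units; beyond the scatter) changes the aromatic ring portion alone, and it replaced 2-methoxyphenyl with 4-chlorophenyl, a larger change than methoxy to methyl at the same position. The steps from compound 1 alter the linkage as well, so they say little here. Within the data shown here, no measured pair tests methyl against methoxy directly. A change within the scatter, or a small rise in number, is therefore expected, with a 1.4-fold higher number from compound 2 to compound 4 (0.16 log units; within the scatter) as the estimated step.

Compound 4 is expected to give 18000 nM in this assay, within a range from 8000 nM to 40000 nM.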

Compound 4, half-maximal inhibitory concentration: 87700 nM
Estimate against measurement, compound 4: 4.9-fold (0.69 log units) below, and the stated range ends below it.
By their numbers in this assay, from the lowest: compound 2; then compound 3; then compounds 4 and 1 (each within the scatter of the next).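

In this assay, replacing methoxy with methyl on this aromatic carbon, ortho to a large group, removes only one heavy atom and one hydrogen-bond acceptor, yet it gives a 7.0-fold higher number from compound 2 to compound 4 (0.85 log units; beyond the scatter), so this position responds strongly to a small edit. The 2-methylphenyl group also compares poorly with the 4-chlorophenyl group, with a 3.2-fold higher number from compound 3 to compound 4 (0.50 log units; beyond the scatter), which shows that the two rings on the double-bonded linkage are far from interchangeable. The double-bonded linkage is not enough on its own to give a low number either: a 1.1-fold lower number from compound 1 to compound 4 (0.06 log units; within the scatter) places compound 4 within the scatter of compound 1, which has a saturated linkage and a methoxy group, and nothing available here explains the size of the step from methoxy to methyl.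

From the compounds shown here alone, it remains open whether the oxygen of the methoxy group is what matters, a question that a hydroxyl, an ethoxy or a chlorine on the same aromatic carbon could help to answer. The compounds shown also leave open whether the same swap would have as large a step on the saturated linkage of compound 1.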